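Fluoro for Methyl on the Oxadiazole Aryl of Compound 3

The compounds below may be only part of what the source reports. "The series", "measured", "known", "first", "only" and "open" are said of these compounds alone.

The measured compounds:
- compound 1, `CCN(CC)c1ccc(-n2cc(-c3ccc(C)c(Nc4nccc(-c5cccnc5)n4)c3)nn2)cc1`, in a functional assay on KG-1a cells (Homo sapiens) for inhibition, read by MTT assay, with a stated time of 72 h (a higher number here means a weaker inhibitor, a lower number a stronger inhibitor), compound 1 gives 2930 nM.
- compound 2, `Cc1ccc(-n2cc(-c3cc(C(F)(F)F)cc(C(F)(F)F)c3)nn2)cc1Nc1nccc(-c2cccnc2)n1`, in this assay compound 2 gives 9930 nM.
- compound 3, `Cc1ccc(-c2nnc(-c3ccc(C)c(C(F)(F)F)c3)o2)cc1Nc1nccc(-c2cccnc2)n1`; for compound 3 this assay reports only a limit, > 30000 nM.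

Compound 3 stands at the weak end of the three values shown: the limit at which it sits, (the limit of > 30000 nM in this assay, at which 1 of the 3 values shown sits), is the upper edge of what the assay reports, while compound 1 and compound 2 each yield a number. Compound 4, `Cc1ccc(-c2nnc(-c3ccc(F)c(C(F)(F)F)c3)o2)cc1Nc1nccc(-c2cccnc2)n1`, differs from compound 3 in one place: fluoro in place of methyl on an aromatic carbon. Within the data shown here, no pair of measured compounds separated by a single change is available, so no measured step sets a scale for this exchange. A change of one heavy atom at this position is expected to leave the value near or beyond the limit, with no shift beyond the scatter in either direction. The step from compound 3 to compound 4 is expected to read a number no higher from compound 3 to compound 4 (the limit leaves the size open). Compound 4 is therefore estimated at 30000 nM, with a range from 10000 nM to 100000 nM.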

Compound 4, half-maximal inhibitory concentration: > 30000 nM
Compound 4: a limit, no number (the forecaster's own chance of this, stated with the estimate: 60%); the middle value lies on the limit itself.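

In this assay compound 3 and compound 4 each give only a limit, so no step can be read between them: the limit of > 30000 nM in this assay, at which 2 of the 4 values shown sit. The compounds shown leave open how far each lies past that limit, and whether fluoro in place of methyl changes inhibition at all.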